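Bis-sulfonamide series: carboxy to methyl on the aryl sulfonyl

The source may hold more compounds than are shown below. What is called first, only, known or untested is meant among the compounds shown, and "the series" means these compounds.

Compound 1, `O=C(O)c1ccc(S(=O)(=O)Nc2ccc(NS(=O)(=O)c3ccc(F)cc3)cc2)cc1`, is one of three measured members of a shared bis-sulfonamide core. In an assay for inhibition of liver carboxylesterase 1 (Homo sapiens), read by spectrophotometry (a lower number here means a stronger inhibitor, a higher number a weaker inhibitor), compound 1 gives > 100000 nM, which is a limit of the assay and not a number. Compound 2, `O=S(=O)(Nc1ccc(NS(=O)(=O)c2c(F)cccc2F)cc1)c1c(F)cccc1F`, likewise reaches only a limit in this assay, giving > 100000 nM. Compound 3, `O=S(=O)(Nc1c(Cl)c(Cl)c(NS(=O)(=O)c2ccccc2)c(Cl)c1Cl)c1ccccc1`, also stops at a limit in this assay, with > 100000 nM. Among the measured compounds shown here, all three values therefore sit together at the limit of > 100000 nM in this assay, at which 3 of the 3 values shown sit, so compound 1 cannot be placed above or below any other measured compound; the series so far shows no inhibition that the assay can resolve.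

The next compound, compound 4, `Cc1ccc(S(=O)(=O)Nc2ccc(NS(=O)(=O)c3ccc(F)cc3)cc2)cc1`, differs from compound 1 in one place: methyl in place of carboxy on an aromatic carbon. For the measured compounds named here, no measured step carries a resolved number, so nothing here sets a scale for this change. The expectation for compound 4 is a step of an at least 1.6-fold lower number from compound 1 to compound 4 (0.22 log units; that floor lies within the scatter), toward stronger inhibition but most likely still ending at a limit. Compound 4 is estimated at 60000 nM, within 5000 nM to 300000 nM.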

Compound 4, inhibition constant: > 100000 nM
Compound 4 was reported as a limit; the forecaster's own chance of this, stated with the estimate: 65%; at least 1.6-fold (0.22 log units) between middle value and limit.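

In this assay compound 4 gives > 100000 nM, a limit of the assay. Compound 1 and compound 4 both stop at limits, so the step between them cannot be read. The compounds shown leave open whether methyl in place of carboxy changes inhibition, and whether any member of the shared core reaches a resolved number.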